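The source may report more compounds than this note shows. Statements on the series, on what has been measured and on what is new or still open speak of the compounds shown alone.

Compound 1 `O=C(Nc1cccc(F)c1)c1cc(=O)[nH]c2cc(Br)ccc12` carries a bromo group on the shared core, and in a functional assay on KYSE-410 cells (Homo sapiens) for antiproliferative activity, read by MTT assay, with a stated time of 72 h (on this read-out lower numbers stand for stronger inhibition and higher numbers for weaker inhibition), compound 1 gives 7300 nM. Compound 2 `O=C(Nc1cccc(F)c1)c1cc(=O)[nH]c2cc(C3CC3)ccc12` carries a cyclopropyl group at the same position. In this assay compound 2 reaches only > 20000 nM, which is a limit of the assay rather than a number. The move between them is an at least 2.7-fold higher number from compound 1 to compound 2 (0.43 log units; beyond the scatter), and because of the limit of > 20000 nM in this assay, at which 1 of the 2 values shown sits, only its lower bound is known. Compound 2 therefore stands at the weak end of the two values shown, without an exact figure.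

Compound 3 `C#Cc1ccc2c(C(=O)Nc3cccc(F)c3)cc(=O)[nH]c2c1` differs from compound 2 by ethynyl in place of cyclopropyl on an aromatic carbon. Among the measured compounds shown here, no measured step here compares cyclopropyl with ethynyl, so the single step from bromo to cyclopropyl gives only indirect guidance, and it shows that a swap at this position can shift the read-out beyond the scatter. With compound 2 already sitting at a limit, a further change is hard to resolve in either direction. The step is estimated as a number no higher from compound 2 to compound 3 (the limit leaves the size open). Compound 3 is expected to give about 20000 nM, within 6000 nM to 60000 nM, with a substantial chance that the assay again reports only a limit.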

Compound 3, half-maximal inhibitory concentration: 9700 nM
Beside the measured number, compound 3's estimate is 2.1-fold (0.31 log units) above it, and the stated range covers the measured number.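

Swapping cyclopropyl for ethynyl at this position in this assay gives an at least 2.0-fold lower number from compound 2 to compound 3 (0.31 log units; beyond the scatter), so the first direct comparison of these two groups shows that the cyclopropyl result does not extend to every carbon-only group placed here. Ethynyl and bromo, however, cannot be told apart in this read-out, as the swap between them gives a 1.3-fold higher number from compound 1 to compound 3 (0.12 log units; within the scatter), and of the three groups shown only cyclopropyl stands apart from the others. The full size of the step away from cyclopropyl cannot be read because compound 2 is held at a limit of the assay: the limit of > 20000 nM in this assay, at which 1 of the 3 values shown sits.

The compounds shown leave open whether any other group at this position, such as an amine, a carboxylic acid or a longer chain, would bring the number clearly below those of compound 1 and compound 3, since ethynyl gave no gain over bromo. They also leave open whether the match between ethynyl and bromo would hold with a different group on the amide, which stays the same throughout these compounds.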